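This account rests on a few compounds, and the source may have more. Where it says the series, first, only, none or still open, it means among the compounds named here.

Measured compounds and their values in a functional assay on HT-29 cells (Homo sapiens) for antiproliferative activity, read by sulforhodamine B assay, with a stated time of 48 h; a lower number here means a stronger inhibitor, a higher number a weaker inhibitor:
compound 1 `CCC(=O)Nc1cccc(S(=O)(=O)Oc2ccccc2C(C)C)c1` gives 22000 nM
compound 2 `CCC(=O)Nc1ccc(S(=O)(=O)Oc2ccccc2C(C)C)cc1` gives 7400 nM
compound 3 `CCC(=O)Nc1ccc(S(=O)(=O)Oc2ccccc2I)cc1` gives 11000 nM

Compound 2 has the lowest of these three numbers in this assay. Compound 3 stands nearest to it: a 1.5-fold higher number from compound 2 to compound 3 (0.17 log units; within the scatter), a step within the scatter, so the two cannot be ranked against each other. Compound 1 stands furthest away, and the gap between its value and that of compound 2 lies beyond the scatter, so compound 1 is the weaker of the two.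

Compound 4 `CC(C)c1ccccc1OS(=O)(=O)c1ccc(NC(=O)C(C)(C)C)cc1` is the next compound, not yet measured. It differs from compound 2 in one place: tert-butyl in place of ethyl on a carbonyl carbon. Among the measured compounds shown here, none of the measured steps touches this amide end of the molecule. For the measured compounds named here, the only step on record, a 1.5-fold higher number from compound 2 to compound 3 (0.17 log units; within the scatter), concerns the other ring and stayed within the scatter. There is therefore nothing in the measured series that points to a change beyond the scatter in either direction for compound 4, and the expectation rests on compound 2 alone.

Compound 4 is thus expected to give about 7400 nM in this assay, with a range from 3000 nM to 18000 nM, which is an expected step of no change at the digits printed from compound 2 to compound 4 (within the scatter).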

Compound 4, half-maximal inhibitory concentration: 15000 nM
The estimate for compound 4 lay 2.0-fold (0.31 log units) below the measured number, and the stated range covers the measured number.
By their numbers in this assay, from the lowest: compounds 2, 3, 4 and 1 (each within the scatter of the next, the first and the last beyond it).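

The amide end had not been touched by any earlier step, and it turns out not to be indifferent to what it carries. In this assay, tert-butyl in place of ethyl on the carbonyl carbon gives a 2.0-fold higher number from compound 2 to compound 4 (0.31 log units; beyond the scatter), a modest step towards a weaker inhibitor, so compound 2 keeps the better number of this pair. The group that enters has 4 carbon atoms where the one that leaves has 2, and neither has a ring, a hydrogen-bond donor, a hydrogen-bond acceptor or a net charge, yet no measurement shown here says why the number moves.

This single step gives only one direction at this position, and it cannot show whether the trend continues with a methyl group, a longer straight chain such as butyl, or a small ring such as cyclopropyl. It also leaves open how a group carrying an amine or a carboxylic acid would behave on the same carbonyl carbon, and whether any replacement for ethyl could give a lower number than compound 2.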